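The source may hold more compounds than are shown below. What is called first, only, known or untested is meant among the compounds shown, and "the series" means these compounds.

Measured so far in a functional assay on HeLa cells (Homo sapiens) for antiproliferative activity, with a stated time of 48 h; on this read-out higher numbers stand for weaker inhibition and lower numbers for stronger inhibition:

- compound 1 `C=C(Br)C(=O)Nc1ccc(C(=O)/C=C/c2cccc(OC)c2)cc1` gives 500 nM
- compound 2 `Nc1ccc(/C=C/C(=O)c2ccc(Br)cc2)cc1` gives 49000 nM
- compound 3 `COc1cccc(/C=C/C(=O)c2ccc(N)cc2)c1` gives 19000 nM

Among these three, compound 3 holds the middle place at 19000 nM on this assay, with compound 1 lower at 500 nM and compound 2 higher at 49000 nM in the same test. Compound 4 `COc1cccc(/C=C/C(=O)c2ccc(N)cc2)c1OC` is compound 3 with a single change, methoxy in place of hydrogen on an aromatic carbon in all. This is methoxy in place of hydrogen on an aromatic carbon, ortho to a large group and ortho to a methoxy group.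

Within the data shown here, only one measured step bears on the series, a 38-fold higher number from compound 1 to compound 3 (1.58 log units; beyond the scatter) as the large change seen so far. It concerns the group on the nitrogen, however, and compound 4 keeps that nitrogen as compound 3 has it. Among the measured compounds shown here, no measured pair tests an added methoxy, so the data give no direct size for this change. On that footing, no step beyond the scatter is expected in this assay, and neither direction is favoured. The expected step is a 1.1-fold higher number from compound 3 to compound 4 (0.02 log units; within the scatter) with wide uncertainty around it. For compound 4 the estimated value is 20000 nM with a range from 7000 nM to 50000 nM expected.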

Compound 4, half-maximal inhibitory concentration: 6800 nM
Compound 4: the middle estimate sits 2.9-fold (0.47 log units) above what was measured; the whole stated range lies above it.
By their numbers in this assay, from the lowest: compound 1; then compound 4; then compound 3; then compound 2.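

In this assay, among these compounds, the step of a 2.8-fold lower number from compound 3 to compound 4 (0.45 log units; beyond the scatter) is the first measured evidence on this position, and it shows that methoxy in place of hydrogen on an aromatic carbon, ortho to a large group and ortho to a methoxy group, can shift the number beyond the scatter toward stronger inhibition. The nitrogen stays as it is in compound 3, so this shift comes from the ring substitution alone and shows that the aromatic ring, not only the group on the nitrogen, affects the read-out. It remains modest beside the large step of a 38-fold higher number from compound 1 to compound 3 (1.58 log units; beyond the scatter) on that nitrogen, and no measurement available here accounts for the gain from the added methoxy.

The compounds shown leave open whether this gain is particular to methoxy or would also appear with a hydroxy group, an ethoxy group or a fluorine atom at the same place. They also leave open whether the added methoxy would lower the number to a similar extent in a compound carrying (1-bromoethenyl)carbonyl on the nitrogen, as compound 1 does.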